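This account rests on a few compounds, and the source may have more. Where it says the series, first, only, none or still open, it means among the compounds named here.

Measured so far:
- compound 1, `[N-]=[N+]=N[C@@H]1[C@@H](O)[C@H](n2cnc3c(NC4CCCC4)ncnc32)O[C@@H]1CO`: 8470 nM in an assay on cell membranes for binding affinity to adenosine receptor A1 (Rattus norvegicus), in the absence of a further agent; a higher number here means a weaker inhibitor, a lower number a stronger inhibitor
- compound 2, `O=C(CCc1ccccc1)N[C@@H]1[C@@H](O)[C@H](n2cnc3c(NC4CCCC4)ncnc32)O[C@@H]1CO`: 370 nM in this assay

For the measured compounds named here, compound 2 holds the lower of the two numbers measured in this assay; the only neighbour is compound 1, and the step of a 23-fold lower number from compound 1 to compound 2 (1.36 log units; beyond the scatter) separates them, well beyond the scatter. Going by the values given here, that step replaces an azido group with a (phenethylcarbonyl)amino group on a saturated ring carbon and is the one measured step.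

Compound 3, `O=C(CCCc1ccccc1)N[C@@H]1[C@@H](O)[C@H](n2cnc3c(NC4CCCC4)ncnc32)O[C@@H]1CO`, is not yet measured in this assay. The change from compound 2 is benzyl in place of phenyl on a saturated chain carbon, two bonds along the chain from a carbonyl carbon; the same difference, cut one bond further out, reads phenethylcarbonyl to (3-phenylpropyl)carbonyl. Among the compounds with values here, no measured step tests a lengthening of this chain; the step of a 23-fold lower number from compound 1 to compound 2 (1.36 log units; beyond the scatter) concerns the presence of the whole amide group, not its length, so it bears on compound 3 only loosely. With nothing measured on chain length, the expectation is a step of a 1.1-fold higher number from compound 2 to compound 3 (0.03 log units; within the scatter), which stays within the scatter. Compound 3 is therefore estimated at 400 nM in this assay, with a range of 130 nM to 1300 nM.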

Compound 3, inhibition constant: 130 nM
The estimate for compound 3 lay 3.1-fold (0.49 log units) above the measured number, and the stated range covers the measured number.
By their numbers in this assay, from the lowest: compound 3; then compound 2; then compound 1.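

Replacing phenyl with benzyl on the saturated chain carbon, two bonds along the chain from the carbonyl carbon, gives a 2.8-fold lower number from compound 2 to compound 3 (0.45 log units; beyond the scatter) in this assay, so the length of the chain carrying the phenyl ring matters at this position, a point the azido-to-amide step could not address. Of the three compounds, compound 3 now holds the lowest number, 130 nM, and phenethylcarbonyl to (3-phenylpropyl)carbonyl is a modest change that still lies beyond the scatter. Nothing available explains why the longer chain gives the lower number.

From the compounds shown here alone, two chain lengths give a direction but neither a trend nor an optimum, so it remains open whether a longer chain, such as (4-phenylbutyl)carbonyl, would lower the number further or reverse the step. Also open, going by these compounds, is whether the phenyl ring is needed at all, which a plain hexanoyl amide would test, and how a free amine in place of the amide would compare on the same core.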